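Methoxy in Place of Fluoro: Expected Cytotoxicity of Compound 4

A few compounds are considered here, and "the series" means these few. Any claim that something is new, unique, unknown or untested is made for them only; others in the source may bear on it.

Compound 1 `Fc1ccc(-c2nc3cc(C(F)(F)F)ccc3[nH]2)cc1` is the only one of the three measured compounds that yields an actual number in an ADME assay on MDBK cells (Bos taurus) for cytotoxicity, read by MTT assay, with a stated time of 96 h (on this read-out lower numbers stand for higher toxicity in this test and higher numbers for lower toxicity in this test), where compound 1 gives 19000 nM. Compound 2 `CC(=O)Nc1ccc(-c2nc3cc([N+](=O)[O-])ccc3[nH]2)cc1` reaches only a limit of the assay, > 100000 nM. Compound 3 `CCC(=O)Nc1ccc(-c2nc3cc(C(F)(F)F)ccc3n2C)cc1` likewise reaches only a limit of the assay, > 100000 nM. Two of the three values therefore sit at the limit of > 100000 nM in this assay, at which 2 of the 3 values shown sit. Compound 4 `COc1ccc(-c2nc3cc(C(F)(F)F)ccc3[nH]2)cc1` differs from compound 1 by methoxy in place of fluoro on an aromatic carbon. Going by the values given here, no step between measured compounds is available. The step from compound 1 to compound 4 in this assay is expected to be small, toward lower toxicity, and probably not beyond the scatter, a 1.6-fold higher number from compound 1 to compound 4 (0.20 log units; within the scatter). Compound 4 is accordingly estimated at 30000 nM, within 10000 nM to 100000 nM.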

Compound 4, half-maximal cytotoxic concentration: > 100000 nM
Compound 4 ended at the assay's limit; the forecaster's own chance of this, stated with the estimate: 30%; middle value at least 3.3-fold (0.52 log units) away from the limit.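

The earlier compounds offered no step in one place, whereas here a single change on the shared core is shown to matter: in this assay, methoxy in place of fluoro at this position gives an at least 5.2-fold higher number from compound 1 to compound 4 (0.72 log units; beyond the scatter). Compound 4 gives > 100000 nM, which is a limit of the assay and not a number. Compound 1 therefore remains the only compound with a measured number: the limit of > 100000 nM in this assay, at which 3 of the 4 values shown sit.

On these data alone, how far the true value of compound 4 lies past that limit stays open. So does whether a hydroxyl, an amine or a longer chain such as ethoxy at this position would also reach the limit.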